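This account rests on a few compounds, and the source may have more. Where it says the series, first, only, none or still open, it means among the compounds named here.

Values in an in vivo ADME assay on the whole organism (strain Sprague-Dawley) for pharmacokinetics, with Rattus norvegicus as the target; a higher number here means that a larger share of the oral dose reaches the circulation, a lower number that a smaller share of the oral dose reaches the circulation:
- compound 1 `O=C1[C@@H](NS(=O)(=O)c2ccc3c(Cl)c[nH]c3c2)CCN1c1ccc2c(c1)CCNC2`: < 1% (a limit)
- compound 2 `O=C1[C@@H](NS(=O)(=O)c2ccc3cc[nH]c3c2)CCN1c1ccc2c(c1)CCNC2`: < 1% (a limit)
- compound 3 `O=C1[C@@H](NS(=O)(=O)c2ccc3c(Cl)c[nH]c3c2)CCN1c1ccc2c(c1F)CCNC2`: 7%

Compound 1 has no number here, only the limit < 1%. For the measured compounds named here, the series so far shows (the limit of < 1% in this assay, at which 2 of the 3 values shown sit).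

Compound 4 `O=C1[C@@H](NS(=O)(=O)c2ccc3c(Cl)c[nH]c3c2)CCN1c1cc2c(cc1F)CNCC2` comes from compound 1 by one structural change: fluoro in place of hydrogen on an aromatic carbon.

Two measured steps are available. The first, a step that the two limits leave unreadable from compound 1 to compound 2, concerns the chloro and not the fluoro, so it gives no guide here. The second, a number at least 6 percentage points higher from compound 1 to compound 3 (that floor lies within the scatter), is the closer precedent: it is the same exchange of hydrogen for fluoro, but on a different aromatic carbon of the core. Going by the values given here, with only this one precedent, and at another carbon, a small gain in this assay is expected for compound 4, perhaps not clearly beyond the scatter. The estimated step runs a number at least 3 percentage points higher from compound 1 to compound 4 (that floor lies within the scatter). For compound 4 the expected value is 4%. The estimated range for compound 4 is 1% to 12%.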

Compound 4, oral bioavailability: 6%
Compound 4: middle estimate off by 2 percentage points, on the low side; the measured number falls inside the stated range.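

In this assay, fluoro in place of hydrogen on an aromatic carbon ortho to a large group gives a number at least 5 percentage points higher from compound 1 to compound 4 (that floor lies within the scatter). The exchange now yields a readable number at a second aromatic carbon of the shared core, not only at the carbon carrying fluoro in compound 3: compound 3 gives 7% and compound 4 gives 6%. The true size of the step remains unread, as its starting point is a limit and not a number: the limit of < 1% in this assay, at which 2 of the 4 values shown sit.

Open, from the compounds shown here alone, is whether nitrile, methoxy or a methyl group on this same aromatic carbon gives a readable number in this assay as fluoro does. Also open, going by these compounds, is whether fluoro on this carbon gives a readable number with hydrogen in place of the chloro, and whether two fluoro groups together change the picture.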